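The compounds below may be only part of what the source reports. "The series", "measured", "known", "first", "only" and "open" are said of these compounds alone.

Compound 1 `O=C(CCCCCc1ccc(Cl)cc1)N1CCOC1=O` gives 4600 nM in an assay on HEK293 cells for inhibition of N-acylethanolamine-hydrolyzing acid amidase (Rattus norvegicus), read by LC-MS, with a stated time of 30 min; a lower number here means a stronger inhibitor, a higher number a weaker inhibitor. Compound 2 `O=C(CCCCCc1ccc(O)cc1)N1CCOC1=O` gives 61 nM in this assay. The change hydroxy in place of chloro on an aromatic carbon produces a 75-fold lower number from compound 1 to compound 2 (1.88 log units; beyond the scatter). Compound 3 `O=C(CCCCCc1ccccc1Cl)N1CCOC1=O` has the same atoms as compound 1 joined differently, and the difference between the two cores is not broken down here. In this assay compound 3 reaches only a limit, > 20000 nM. Compound 4 `O=C(CCCCCc1ccccc1O)N1CCOC1=O` has not been measured. Within the data shown here, its change from compound 3, (hydroxy in place of chloro on an aromatic carbon), is the same kind of change as the one from compound 1 to compound 2, but the place differs: ortho to a large group rather than para to a large group. Because compound 3 sits at the limit of > 20000 nM in this assay, at which 1 of the 3 values shown sits, that pair alone cannot size the step. Resting on a 75-fold lower number from compound 1 to compound 2 (1.88 log units; beyond the scatter), a step of an at least 8.0-fold lower number from compound 3 to compound 4 (0.90 log units; beyond the scatter) is expected. Compound 4 is therefore estimated at 2500 nM, between 300 nM and 20000 nM.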

Compound 4, half-maximal inhibitory concentration: > 20000 nM
Compound 4 ended at the assay's limit; the forecaster's own chance of this, stated with the estimate: 30%; middle value at least 8.0-fold (0.90 log units) from the limit.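

No step can be read between compound 3 and compound 4, since both stand at a limit of the assay: the limit of > 20000 nM in this assay, at which 2 of the 4 values shown sit. The compounds shown leave open what hydroxy in place of chloro does ortho to a large group.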